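Adding a phenyl Ring to a Nitrone: Compound 4

This account rests on a few compounds, and the source may have more. Where it says the series, first, only, none or still open, it means among the compounds named here.

Of the compounds shown here, three have been measured in a functional assay, read by spectrophotometry, with a stated time of 10 min; on this read-out higher numbers stand for an effect only at larger amounts of compound and lower numbers for an effect already at smaller amounts. Compound 1 `C/[N+]([O-])=C1\C(=O)Nc2ccc([N+](=O)[O-])cc21` gives 1200 nM. Compound 2 `C/[N+]([O-])=C1\CCc2ccccc21` gives 1300 nM, and compound 3 `C/[N+]([O-])=C1\CCc2cc(F)ccc21` gives 1800 nM. Compound 2 stands second highest of the three numbers; its nearest neighbour is compound 1 and its furthest is compound 3, and both gaps are within the scatter, so the three compounds cannot be told apart on these numbers.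

Compound 4 `[O-]/[N+](Cc1ccccc1)=C1/CCc2ccccc21` has not yet been measured in this assay. Compared with compound 2 the change is phenyl in place of hydrogen on a saturated chain carbon bound to a double-bonded nitrogen. For the measured compounds named here, only one measured step connects two of the compounds: from compound 2 to compound 3, which is a 1.4-fold higher number from compound 2 to compound 3 (0.14 log units; within the scatter). Going by the values given here, that step swaps a hydrogen on an aromatic carbon for fluoro, and it says nothing about a phenyl placed on the chain carbon bound to the double-bonded nitrogen, which no measured pair covers. Among the compounds with values here, with no step bearing on this change, the expectation for compound 4 in this assay is a number close to compound 2, with the step expected to be no change at the digits printed from compound 2 to compound 4 (within the scatter), meaning none beyond the scatter, though the range is kept wide. Compound 4 is therefore estimated at 1300 nM, between 500 nM and 3500 nM.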

Compound 4, half-maximal effective concentration: 1200 nM
Compound 4: the middle estimate sits 1.1-fold (0.03 log units) above what was measured, and the stated range covers the measured number.
By their numbers in this assay, from the lowest: compounds 1, 4, 2 and 3 (each within the scatter of the next).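

In this assay, phenyl in place of hydrogen on a saturated chain carbon bound to a double-bonded nitrogen gives a 1.1-fold lower number from compound 2 to compound 4 (0.03 log units; within the scatter), so the two compounds cannot be told apart on this read-out. For the compounds shown here, the only earlier step concerned a hydrogen on an aromatic carbon, whereas this one shows that the chain carbon can carry a far larger group, with 6 heavy atoms in one six-membered aromatic ring of carbon, without the number moving beyond the scatter. No measurement at hand bears on why the number holds at this size of change.

From the compounds shown here alone, this remains a single group at a single place, so it is open whether an amine, a carboxylic acid or a longer chain on the same carbon would also stay within the scatter of compound 2. Going by these compounds, it is also open whether phenyl at this place would give the same result alongside the fluoro of compound 3 or on the core of compound 1.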